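The source may hold more compounds than are shown below. What is called first, only, known or untested is meant among the compounds shown, and "the series" means these compounds.

Compound 1 `COc1ccc(C2CC(c3ccccc3)=NN2C2=NC(=O)/C(=C3\C(=O)Nc4ccccc43)S2)cc1` is the weaker of the two measured compounds: in a functional assay on cells (Cancer cell lines, Homo sapiens) for cytotoxicity, read by sulforhodamine B assay, with a stated time of 48 h (on this read-out lower numbers stand for stronger inhibition of growth and higher numbers for weaker inhibition of growth), compound 1 gives 6040 nM, the highest of the two numbers in hand. For the measured compounds named here, its only measured neighbour is compound 2 `COc1ccc(C2CC(c3ccccc3)=NN2C2=NC(=O)/C(=C3\C(=O)Nc4ccc(Br)cc43)S2)cc1`, which in this assay gives 510 nM; the step of a 12-fold lower number from compound 1 to compound 2 (1.07 log units; beyond the scatter) is large and comes from bromo in place of hydrogen on an aromatic carbon of the core, a change that touches a different part of the molecule from the one considered here.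

Compound 3 `CN(C)c1ccc(C2CC(c3ccccc3)=NN2C2=NC(=O)/C(=C3\C(=O)Nc4ccccc43)S2)cc1` differs from compound 1 by dimethylamino in place of methoxy on an aromatic carbon, so the change is dimethylamino in place of methoxy on an aromatic carbon, para to a large group. Going by the values given here, no measured step varies this position: the step from compound 1 to compound 2 leaves the methoxyphenyl untouched, so it gives no guide to the size or direction of an effect here. With nothing in the data pointing either way, the expectation for compound 3 is a step of a 1.0-fold lower number from compound 1 to compound 3 (0.00 log units; within the scatter), that is, no change beyond the scatter. Compound 3 is therefore estimated at 6000 nM, with a range from 2000 nM to 18000 nM in this assay.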

Compound 3, concentration for total growth inhibition: 25200 nM
The estimate for compound 3 lay 4.2-fold (0.62 log units) below the measured number, outside the stated range (above it).
By their numbers in this assay, from the lowest: compound 2; then compound 1; then compound 3.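

For the compounds shown here, the 4-methoxyphenyl group of compound 1 proves open to change in this assay: the exchange for 4-(dimethylamino)phenyl gives a 4.2-fold higher number from compound 1 to compound 3 (0.62 log units; beyond the scatter) and is the first measured step at this place, a modest one towards weaker inhibition of growth. The aromatic carbon para to a large group therefore responds to the group it carries, which the bromo step on the core could not show, and of the two groups measured here, methoxy stands with the lower number. That rests on a single pair, and no measurement on these compounds accounts for the step.

The compounds shown leave open how a primary amine, a hydroxyl, an ethoxy group or a plain hydrogen at the same place would compare with methoxy and dimethylamino, and so whether the number follows any trend across such groups. They also leave open whether the gain seen with bromo on the core would carry over to a compound bearing the 4-(dimethylamino)phenyl group, or whether the two changes would act independently of each other.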